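This account rests on a few compounds, and the source may have more. Where it says the series, first, only, none or still open, it means among the compounds named here.

Measured compounds, all in a toxicity assay on MT4 cells (Homo sapiens) for cytotoxicity, read by MTT assay, with a stated time of 5 days; on this read-out lower numbers stand for higher toxicity in this test and higher numbers for lower toxicity in this test:
Compound 1 `Cc1cc(-c2ccc(C#N)cc2)cc(C)c1Oc1nc(Nc2ccc(C#N)c(F)c2)nc2sccc12`; for compound 1 the reading is the limit > 254000 nM, a limit of the assay rather than a number.
Compound 2 `Cc1cc(-c2ccc(C#N)cc2)cc(C)c1Oc1nc(Nc2ccc(C#N)nc2)nc2sccc12`; compound 2 gives 181000 nM.
Compound 3 `N#C/C=C/c1cc(F)c(Oc2nc(Nc3ccc(C#N)c(F)c3)nc3c2COC3)c(F)c1`; compound 3 gives 243000 nM.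

Within the data shown here, the one change measured is 6-cyanopyridin-3-yl in place of 4-cyano-3-fluorophenyl on a nitrogen on an aromatic ring, giving an at least 1.4-fold lower number from compound 1 to compound 2 (0.14 log units; that floor lies within the scatter); that floor rests on the limit of > 254000 nM in this assay, at which 1 of the 3 values shown sits, and says nothing more than that the two sit near each other. Compound 4 `N#C/C=C/c1cc(F)c(Oc2nc(Nc3ccc(C#N)nc3)nc3c2COC3)c(F)c1`, not yet measured, carries the same change on the core of compound 3: 6-cyanopyridin-3-yl in place of 4-cyano-3-fluorophenyl on a nitrogen on an aromatic ring, at the same place. How the cores of compound 1 and compound 3 differ is not broken down here.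

In this assay the step from compound 3 to compound 4 is expected to be a 1.3-fold lower number from compound 3 to compound 4 (0.11 log units; within the scatter), since the measured step from compound 1 to compound 2 shows only a floor within the scatter. Compound 4 is estimated at 190000 nM, between 110000 nM and 300000 nM.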

Compound 4, half-maximal cytotoxic concentration: 243000 nM
Compound 4: the middle estimate sits 1.3-fold (0.11 log units) below what was measured, within the range that was stated.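

In this assay, 6-cyanopyridin-3-yl in place of 4-cyano-3-fluorophenyl on a nitrogen on an aromatic ring gives no change at the digits printed from compound 3 to compound 4 (within the scatter). Set beside the earlier core, the change reads: the same change on two cores in this assay, an at least 1.4-fold lower number (0.14 log units; that floor lies within the scatter) from compound 1 to compound 2 and no change at the digits printed (within the scatter) from compound 3 to compound 4; the limit leaves it open whether they differ. Compound 1 carries a limit and not a number, so the two cores give no measured size of the change to compare, and transfer between them is neither confirmed nor ruled out: the limit of > 254000 nM in this assay, at which 1 of the 4 values shown sits.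

The compounds shown leave open how the change reads on a core where both partners give numbers. They also leave open whether an amine or a carboxylic acid in place of the nitrile would alter the reading in this assay.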